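The source may report more compounds than this note shows. Statements on the series, on what has been measured and on what is new or still open speak of the compounds shown alone.

Compound 3 `COc1cc(-c2nn(-c3cccc(NC(=O)Nc4cccc(C(F)(F)F)c4)c3)cc2-c2ccncc2)ccc1Cl` gives 1650 nM in a functional assay on LOX IMVI cells (Homo sapiens) for inhibition, read by sulforhodamine B assay, with a stated time of 48 h (a higher number here means a weaker inhibitor of growth, a lower number a stronger inhibitor of growth), the lowest of the two numbers shown. Compound 2 `COc1cc(-c2nn(-c3cccc(NC(=O)Nc4ccc(Cl)c(Cl)c4)c3)cc2-c2ccncc2)ccc1Cl` gives 2620 nM, and a 1.6-fold lower number from compound 2 to compound 3 (0.20 log units; within the scatter). Compound 1 `COc1cc(-c2nn(-c3cccc(NC(=O)c4cccc(C(F)(F)F)c4)c3)cc2-c2ccncc2)ccc1Cl` reports only a limit, > 50000 nM. Compound 4 `COc1cc(-c2nn(-c3cccc(NC(=O)c4ccc(Cl)c(C(F)(F)F)c4)c3)cc2-c2ccncc2)ccc1Cl` differs from compound 3 by 4-chloro-3-(trifluoromethyl)phenyl in place of (3-(trifluoromethyl)phenyl)amino on a carbonyl carbon. Among the compounds with values here, the steps that bear on this are an at least 30-fold lower number from compound 1 to compound 3 (1.48 log units; beyond the scatter) and an at least 19-fold lower number from compound 1 to compound 2 (1.28 log units; beyond the scatter), each moving from a ring bound directly to the carbonyl carbon to a ring linked through an amide-type nitrogen; compound 4 reverses that move, so a large rise in this assay is expected. Compound 4 is therefore estimated at 40000 nM, between 10000 nM and 150000 nM. That means a 24-fold higher number from compound 3 to compound 4 (1.38 log units; beyond the scatter) is expected. Given (the limit of > 50000 nM in this assay, at which 1 of the 3 values shown sits), compound 4 may well be reported only as a limit.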

Compound 4, concentration for total growth inhibition: > 32500 nM
Compound 4 gave a limit, no number; the forecaster's own chance of this, stated with the estimate: 60%; the middle value does not contradict the limit.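

In this assay the 4-chloro-3-(trifluoromethyl)phenyl group on the carbonyl carbon gives an at least 19-fold higher number from compound 3 to compound 4 (1.29 log units; beyond the scatter) and an at least 12-fold higher number from compound 2 to compound 4 (1.09 log units; beyond the scatter), so the loss seen with compound 1 is not confined to its 3-(trifluoromethyl)phenyl ring. Compound 4 is reported only as a limit: the limit of > 32500 nM in this assay, at which 1 of the 4 values shown sits. Compound 1 is also reported only as a limit, so the step of chloro in place of hydrogen on an aromatic carbon cannot be read: the limit of > 50000 nM in this assay, at which 1 of the 4 values shown sits. The compounds shown leave open how weak compound 4 actually is. Also open, as far as these compounds go, is whether a methylene group or an oxygen atom in place of the amide-type nitrogen, linking the ring to the carbonyl carbon, would give a measurable number as compound 2 and compound 3 do.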